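A Second Methyl on the Central Ring

The source may hold more compounds than are shown below. What is called first, only, known or untested is meant among the compounds shown, and "the series" means these compounds.

Compound 1 `Cc1cc(C(=O)c2ccccc2)ccc1OCC(=O)Nc1nc(-c2ccccc2)cs1` gives 24000 nM in a functional assay on Ehrlich cells (Mus musculus) for cytotoxicity, read by MTT assay, with a stated time of 48 h; on this read-out lower numbers stand for stronger inhibition and higher numbers for weaker inhibition; of the two numbers recorded it is the smaller, but compound 2 `Cc1ccc(C(=O)c2ccc(OCC(=O)Nc3nc(-c4ccccc4)cs3)c(C)c2)cc1`, which gives 29900 nM, lies within the scatter of it. Compound 3 `Cc1cc(C(=O)c2ccccc2)cc(C)c1OCC(=O)Nc1nc(-c2ccccc2)cs1` differs from compound 1 by methyl in place of hydrogen on an aromatic carbon, sitting ortho to a large group, meta to a benzoyl group and meta to a methyl group. Within the data shown here, the only step that bears on this change, a 1.2-fold higher number from compound 1 to compound 2 (0.10 log units; within the scatter), was also a methyl in place of hydrogen on an aromatic carbon and stayed within the scatter. The step to compound 3 is therefore expected to be a 1.1-fold higher number from compound 1 to compound 3 (0.03 log units; within the scatter), nothing beyond the scatter. Compound 3 is estimated at 26000 nM, with a range from 12000 nM to 55000 nM.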

Compound 3, half-maximal inhibitory concentration: 22700 nM
Compound 3: the middle estimate sits 1.1-fold (0.06 log units) above what was measured, and the stated range covers the measured number.
By their numbers in this assay, from the lowest: compounds 3, 1 and 2 (each within the scatter of the next).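

In this assay, methyl in place of hydrogen on this aromatic carbon, ortho to a large group, gives a 1.1-fold lower number from compound 1 to compound 3 (0.02 log units; within the scatter), which lies within the scatter. So a methyl at this second place on the compounds, like the earlier one at a different place, leaves the number within the scatter. Nothing available explains why this position tolerates the change.

Methyl is the only group shown here, so what an amine, a carboxylic acid or a longer chain would do at this position stays open. Whether a group at this position can move the number beyond the scatter also remains unanswered.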